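This account rests on a few compounds, and the source may have more. Where it says the series, first, only, none or still open, it means among the compounds named here.

Measured so far:
- compound 1, `O=C(NO)c1ccc(NC2CCN(c3ccc(Cl)c(Cl)c3)C2=O)cc1` — 4300 nM in an assay on A549 cells for inhibition of protein deacetylase HDAC6 (Homo sapiens), read by ELISA, with a stated time of 18 h; a higher number here means that more compound is needed for the effect, a lower number that less compound is needed
- compound 2, `CS(=O)(=O)c1ccc(N2CCC(Nc3ccc(C(=O)NO)cc3)C2=O)cc1` — 11900 nM in this assay

Compound 2 stands at the higher of the two numbers in this assay; compound 1 sits lower, and the gap between them lies beyond the usual scatter of repeated measurements. Among the compounds with values here, no step between these two measured compounds has been worked out, so their two values are all that can be said of the pair.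

Compound 3, `O=C(NO)c1ccc(NC2CCN(c3ccc(C(F)(F)F)cc3)C2=O)cc1`, is not yet measured. It differs from compound 2 by a single change: trifluoromethyl in place of methylsulfonyl on an aromatic carbon. The entering group carries no hydrogen-bond acceptors, which places compound 3 closer in this respect to compound 1 than to compound 2, and compound 1 gives 4300 nM. On that basis the step from compound 2 to compound 3 is expected to be a modest one toward a lower number, a 2.2-fold lower number from compound 2 to compound 3 (0.34 log units; beyond the scatter), though a result within the scatter cannot be excluded. Compound 3 is estimated at 5500 nM, with a range from 2000 nM to 15000 nM.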

Compound 3, half-maximal effective concentration in the protein deacetylase HDAC6 assay: 16200 nM
Compound 3: middle estimate off by 2.9-fold (0.47 log units), on the low side; the whole stated range lies below it.
By their numbers in the protein deacetylase HDAC6 assay, from the lowest: compound 1; then compounds 2 and 3 (each within the scatter of the next).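

Within the data shown here, in the protein deacetylase HDAC6 assay, the first single-change step reads a 1.4-fold higher number from compound 2 to compound 3 (0.13 log units; within the scatter), so trifluoromethyl in place of methylsulfonyl, on an aromatic carbon para to a large group, does not separate the two compounds on this read-out, even though the entering group has no hydrogen-bond acceptors and the leaving group has them. In a physicochemical assay for solubility, in phosphate buffer (on this read-out lower numbers stand for lower solubility and higher numbers for higher solubility), the same change does separate them, with compound 2 at 97 ug/mL and compound 3 at 43 ug/mL and with lower solubility on the trifluoromethyl side: the measured solubility of compound 2, 97 ug/mL, and of compound 3, 43 ug/mL, a 2.3-fold lower number (0.35 log units; beyond the scatter). Among these compounds, at this position the change therefore comes with a solubility cost and nothing readable to set against it in the protein deacetylase HDAC6 assay, a contrast between read-outs that the earlier pair, with no step between its members, could not show.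

Open, from the compounds shown here alone, is whether a carboxylic acid or an amine on the same aromatic carbon would move either read-out beyond the scatter. This one step also says nothing about changes elsewhere on the shared core, so no pattern extends beyond this pair.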